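Hydroxy Added Ortho to Methoxy on Compound 3

The source may hold more compounds than are shown below. What is called first, only, known or untested is meant among the compounds shown, and "the series" means these compounds.

Compound 3 `COc1ccc(-c2cn(-c3ccc(OC)c(O)c3)nn2)cc1` is known only to a limit in a functional assay on MDA-MB-231 cells (Homo sapiens) for cytotoxicity, read by MTT assay; a higher number here means a weaker inhibitor, a lower number a stronger inhibitor: compound 3 gives > 100 nM, a limit of the assay (the limit of > 100 nM in this assay, at which 1 of the 3 values shown sits). Compound 1 `COc1ccc(-n2cc(-c3ccc(OC)c(OC)c3)nn2)cc1O` likewise sits at a limit, giving > 1000 nM in this assay. Compound 2 `COc1ccc(-n2cc(-c3ccc(OC)c(O)c3)nn2)cc1` also sits at a limit, giving > 10000 nM in this assay. The step that the two limits leave unreadable from compound 1 to compound 3 is therefore unreadable. Compound 4 `COc1ccc(-c2cn(-c3ccc(OC)c(O)c3)nn2)cc1O` differs from compound 3 by hydroxy in place of hydrogen on an aromatic carbon. Within the data shown here, no measured step with a readable size bears on this change, and every value shown is a limit, so no direction beyond the scatter can be expected. Compound 4 is estimated at 3000 nM in this assay, between 300 nM and 30000 nM, with the step that the limit leaves unreadable from compound 3 to compound 4 expected small.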

Compound 4, half-maximal inhibitory concentration: > 10000 nM
Compound 4 was reported as a limit; the forecaster's own chance of this, stated with the estimate: 70%; at least 3.3-fold (0.52 log units) between middle value and limit.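

No step can be read from compound 1, compound 2 or compound 3 to compound 4, as all four values are limits of the assay. The compounds shown leave open both the size and the direction of any change from hydroxy in place of hydrogen on an aromatic carbon.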